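The source may hold more compounds than are shown below. What is called first, only, known or untested is meant among the compounds shown, and "the series" means these compounds.

Compound 1 `CCCCc1cc2c(=O)c(C(C)=O)c[nH]c2cc1OCCOc1ccccc1`: "not determined" (no result reported)
Compound 2 `CCCCc1cc2c(=O)c(C(=O)O)c[nH]c2cc1OCCOc1ccccc1`: > 20000 nM
Compound 3 `O=c1cc[nH]c2cc(OCCOc3ccccc3)ccc12`: > 20000 nM

In an ADME assay on J774 cells (Mus musculus) for cytotoxicity (on this read-out lower numbers stand for an effect already at smaller amounts and higher numbers for an effect only at larger amounts of compound), compound 3 gives > 20000 nM, which is a limit and not a number. Compound 3 therefore stands at the limit of > 20000 nM in this assay, at which 2 of the 3 values shown sit. Compound 1 offers no comparison, as its entry reads "not determined" (no result reported).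

Compound 4 `CCCCc1cc2c(=O)cc[nH]c2cc1OCCOc1ccccc1` is compound 3 with one change: butyl in place of hydrogen on an aromatic carbon. Among the measured compounds shown here, no measured pair isolates this change. Compound 2, which also carries butyl, gives > 20000 nM, likewise a limit. On that basis, the expected step of a number no higher from compound 3 to compound 4 (the limit leaves the size open) is small and possibly none beyond the scatter, with any shift towards lower numbers. For compound 4 the estimate is 20000 nM, with an expected range from 8000 nM to 40000 nM, and a limit alone is quite possible as the result.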

Compound 4, half-maximal effective concentration: > 20000 nM
Compound 4 was reported as a limit; the forecaster's own chance of this, stated with the estimate: 65%; the middle value sits exactly at the limit.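

Among the compounds shown here, compound 2, compound 3 and compound 4 all end at the same limit, so no step between them can be read: the limit of > 20000 nM in this assay, at which 3 of the 4 values shown sit. What butyl in place of hydrogen does in this assay stays open, as does the concentration at which any of these compounds would show an effect.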